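The compounds below may be only part of what the source reports. "The series", "measured", "known", "first", "only" and "open" are said of these compounds alone.

Measured so far in a functional assay on MIA PaCa-2 cells (Homo sapiens) for inhibition, read by MTT assay, with a stated time of 3 days; on this read-out lower numbers stand for stronger inhibition and higher numbers for weaker inhibition:

Compound 1, `CCN(CC)S(=O)(=O)c1ccc(S(=O)(=O)N2CCC[C@@H](C(=O)NC3CN(C(=O)C4CC4)C3)C2)cc1`, gives 3100 nM.
Compound 2, `CCN(CC)S(=O)(=O)c1ccc(S(=O)(=O)N2CCC[C@@H](C(=O)NC)C2)cc1`, gives 2000 nM.
Compound 3, `CCN(CC)S(=O)(=O)c1ccc(S(=O)(=O)N2CCC[C@@H](C(=O)NC3CN(C(=O)OC(C)(C)C)C3)C2)cc1`, gives 100 nM.

Compound 3 stands lowest of the three numbers in this assay; the two steps that lead down to it are a 20-fold lower number from compound 2 to compound 3 (1.30 log units; beyond the scatter) and a 31-fold lower number from compound 1 to compound 3 (1.49 log units; beyond the scatter). Compound 4, `CCN(CC)S(=O)(=O)c1ccc(S(=O)(=O)N2CCC[C@@H](C(=O)N3CCN(c4nc(C)no4)CC3)C2)cc1`, has not yet been measured. It differs from compound 3 in one place: 4-(3-methyl-1,2,4-oxadiazol-5-yl)piperazin-1-yl in place of (1-(tert-butoxycarbonyl)azetidin-3-yl)amino on a carbonyl carbon.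

Among the measured compounds shown here, two measured steps bear on this. The step of a 31-fold lower number from compound 1 to compound 3 (1.49 log units; beyond the scatter) shows that exchanging only the group on the carbonyl carbon of the azetidine substituent moved the number by a large amount, and the step of a 20-fold lower number from compound 2 to compound 3 (1.30 log units; beyond the scatter) shows that the whole 1-(tert-butoxycarbonyl)azetidin-3-yl group, compared with a plain methyl, carried the same large gain. Compound 4 keeps neither the tert-butoxycarbonyl nor the azetidine, so the number is expected to rise well beyond the scatter, in this assay roughly back toward the range of compound 1 and compound 2, a step estimated as a 15-fold higher number from compound 3 to compound 4 (1.18 log units; beyond the scatter). Compound 4 is therefore estimated at 1500 nM, with a likely range from 300 nM to 6000 nM.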

Compound 4, half-maximal inhibitory concentration: 200 nM
The estimate for compound 4 lay 7.5-fold (0.88 log units) above the measured number, outside the stated range (below it).
By their numbers in this assay, from the lowest: compounds 3 and 4 (each within the scatter of the next); then compounds 2 and 1 (each within the scatter of the next).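

The step of a 2.0-fold higher number from compound 3 to compound 4 (0.30 log units; within the scatter) in this assay shows that a number in this range at this carbonyl carbon does not need the azetidine or the tert-butoxycarbonyl group, since 4-(3-methyl-1,2,4-oxadiazol-5-yl)piperazin-1-yl has neither and also lacks the amide hydrogen. The same group holds its advantage over both other amides, with a 10-fold lower number from compound 2 to compound 4 (1.00 log units; beyond the scatter) against methylamino and a 16-fold lower number from compound 1 to compound 4 (1.19 log units; beyond the scatter) against (1-(cyclopropylcarbonyl)azetidin-3-yl)amino, so two quite different groups now separate from these two compounds. No measurement here explains why these two different groups give such similar numbers.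

Still open, on these data alone, is whether the piperazine or the 3-methyl-1,2,4-oxadiazol-5-yl ring matters more. A piperazine carrying an acetyl group instead of the oxadiazole, or a piperazine with a free amine, would help separate the two.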